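Alkyl to cycloalkyl exchange at the core of compound 1

The source may hold more compounds than are shown below. What is called first, only, known or untested is meant among the compounds shown, and "the series" means these compounds.

Among the measured compounds shown here, compound 1 `CCCCCc1nc(N)n(CC(=O)Nc2ccccc2)c1-c1ccccc1Br` holds the highest of the three numbers so far: in a functional assay on A-375 cells (Homo sapiens) for antiproliferative activity, read by MTT assay, with a stated time of 48 h (on this read-out lower numbers stand for stronger inhibition and higher numbers for weaker inhibition), compound 1 gives 26400 nM. Compound 2 `CCCCCCc1nc(N)n(CC(=O)Nc2ccccc2)c1-c1ccccc1Br` gives 5700 nM, and compound 3 `Nc1nc(CC2CCCC2)c(-c2ccccc2Br)n1CC(=O)Nc1ccccc1` gives 24300 nM. The step of a 1.1-fold lower number from compound 1 to compound 3 (0.04 log units; within the scatter) sits within the scatter, whereas a 4.6-fold lower number from compound 1 to compound 2 (0.67 log units; beyond the scatter) and a 4.3-fold higher number from compound 2 to compound 3 (0.63 log units; beyond the scatter) are modest changes beyond it.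

Compound 4 `Nc1nc(CC2CCCCC2)c(-c2ccccc2Br)n1CC(=O)Nc1ccccc1` differs from compound 1 by cyclohexyl in place of butyl on a saturated chain carbon bound to an aromatic carbon. For the measured compounds named here, two measured steps bear on this. First, a 1.1-fold lower number from compound 1 to compound 3 (0.04 log units; within the scatter) shows that cyclopentyl in place of butyl at the same place left the number where it was. Second, a 4.6-fold lower number from compound 1 to compound 2 (0.67 log units; beyond the scatter) shows that lengthening the chain by a methyl lowered the number modestly. Compound 4 combines a ring at this place with the larger, six-membered ring, so a modest lowering relative to compound 1 is expected rather than none. Compound 4 is therefore estimated at 12000 nM, with a range from 4000 nM to 35000 nM. This estimate amounts to an expected 2.2-fold lower number from compound 1 to compound 4 (0.34 log units; beyond the scatter).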

Compound 4, half-maximal inhibitory concentration: 40600 nM
For compound 4 the middle estimate is 3.4-fold (0.53 log units) below the measured one; the whole stated range lies below it.
By their numbers in this assay, from the lowest: compound 2; then compounds 3, 1 and 4 (each within the scatter of the next).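

The six-membered ring brings no gain at this place: a 1.5-fold higher number from compound 1 to compound 4 (0.19 log units; within the scatter) and a 1.7-fold higher number from compound 3 to compound 4 (0.22 log units; within the scatter) both stay within the scatter, so cyclohexyl reads the same as butyl and as cyclopentyl, and widening the ring from cyclopentyl to cyclohexyl changes nothing that can be read. Only the open pentyl chain of compound 2 stands apart, with a 7.1-fold higher number from compound 2 to compound 4 (0.85 log units; beyond the scatter), so among these four compounds a larger group at this place does not in itself go with a lower number, and the modest gain belongs to pentyl alone. No measurement at hand gives a reason for this difference between the pentyl chain and the rings.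

Still open, from the compounds shown here alone, is whether a longer chain than pentyl lowers the number further or whether compound 2 already marks the end of that trend. Equally open, going by these compounds, is how a cyclopropyl ring, or an amine or carboxylic acid carried on the chain, would read at this place.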